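This account rests on a few compounds, and the source may have more. Where it says the series, first, only, none or still open, it means among the compounds named here.

Measured in an ADME assay on HEK-293T cells (Homo sapiens) for cytotoxicity, read by luminescence, with a stated time of 24 h; a lower number here means that less compound is tolerated, a higher number that more compound is tolerated:
Compound 1 `CCOC(=O)c1cc2sccc2n1Cc1ccc(OC)cc1` gives > 100000 nM as a limit.
Compound 2 `COc1ccc(Cn2c(C(N)=O)cc3sccc32)cc1` gives > 100000 nM as a limit.
Compound 3 `CCOC(=O)C1CCN(C(=O)c2cc3sccc3n2Cc2ccc(OC)cc2)CC1` gives 39000 nM as a number.

Compound 3 alone has a number here. The other two compounds give only the limit of > 100000 nM in this assay, at which 2 of the 3 values shown sit, and nothing more. Compound 4 `COc1ccc(Cn2c(C(=O)N3CCC(C(=O)NCc4ccccc4)CC3)cc3sccc32)cc1` puts benzylamino in place of ethoxy on a carbonyl carbon, a change counted as benzylamino in place of ethoxy on a carbonyl carbon in full. The nearest measured change is a step that the two limits leave unreadable from compound 1 to compound 2 with amino in place of ethoxy on a carbonyl carbon, so it offers no size to carry over. No step beyond the scatter is therefore expected in this assay in either direction. The expected change is a 1.1-fold lower number from compound 3 to compound 4 (0.05 log units; within the scatter) and no larger. For compound 4 the estimate is 35000 nM with a range of 12000 nM to 100000 nM as expected bounds.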

Compound 4, half-maximal cytotoxic concentration: > 100000 nM
Compound 4 gave a limit, no number (the forecaster's own chance of this, stated with the estimate: 20%); middle value at least 2.8-fold (0.45 log units) from the limit.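

In this assay, benzylamino in place of ethoxy on a carbonyl carbon gives an at least 2.5-fold higher number from compound 3 to compound 4 (0.40 log units; beyond the scatter). Going by these compounds alone, this is the first step at this place that can be read, as the earlier step between two limits could not be, and it shows that the benzylcarbamoyl compound is tolerated better than the ethoxycarbonyl compound. The result for compound 4 is a limit, so the step has a floor but no full size: the limit of > 100000 nM in this assay, at which 3 of the 4 values shown sit.

The compounds shown leave open whether a carboxylic acid at this place would also reach the limit. They also leave open whether methylamino, which lacks the aromatic ring of benzylamino, would give the same step.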